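Dropping One Chloro Group: Compound 2 to Compound 4

A few compounds are considered here, and "the series" means these few. Any claim that something is new, unique, unknown or untested is made for them only; others in the source may bear on it.

Measured so far:
compound 1, `CCCn1c(=O)[nH]c2c(cnn2-c2cccc(Cl)c2)c1=N`, 68%
compound 2, `Cn1c(=O)[nH]c2c(cnn2-c2cc(Cl)cc(Cl)c2)c1=N`, 29%
compound 3, `Cn1c(=O)[nH]c2c(cnn2C)c1=N`, 6%

In an assay on membranes from brain for binding affinity to adenosine receptor A1 (Rattus norvegicus), read by radioligand binding, tested at 20 uM (a higher number here means more inhibition at the concentration tested (going by the name of the read-out), a lower number less inhibition), compound 2 stands second highest of the three numbers. Its nearest neighbour is compound 3, whose value is lower by a gap beyond the usual scatter; the furthest is compound 1, whose value is higher, again beyond the scatter.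

Compound 4, `Cn1c(=O)[nH]c2c(cnn2-c2cccc(Cl)c2)c1=N`, has not yet been measured. It differs from compound 2 in one place: hydrogen in place of chloro on an aromatic carbon. Compound 2 therefore carries one chloro group more than compound 4 on its aromatic ring.

Going by the values given here, no pair of measured compounds differs in exactly one place, so no direct step is available to guide the expectation. What can be said is that compound 4 shares its single-chloro aromatic ring with compound 1, which differs from it in carrying a propyl rather than a methyl group on the shared core. In this assay compound 1 gives 68%, while compound 3, with no aromatic ring at all, gives 6%. On this basis a modest increase is expected, of a size a number 11 percentage points higher from compound 2 to compound 4 (beyond the scatter), though the sparse data leave this uncertain. For compound 4 the estimated value in this assay is 40%, with a range from 15% to 65%.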

Compound 4, a percentage reported as inhibition, at one concentration (the size of the read-out at that concentration, not a potency): 53%
Compound 4: middle estimate off by 13 percentage points, on the low side, and the stated range covers the measured number.
By their numbers in this assay, from the lowest: compound 3; then compound 2; then compound 4; then compound 1.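

In this assay, the step from two chloro groups to one on the aromatic ring is a number 24 percentage points higher from compound 2 to compound 4 (beyond the scatter), so at this position, meta to a chloro group, hydrogen gives more inhibition than chloro does in this pair. Going by these compounds alone, this is the first comparison to isolate this ring position, and it shows that adding a second chloro group to the ring does not add inhibition here. The second step, a number 15 percentage points lower from compound 1 to compound 4 (beyond the scatter), isolates the chain on the aromatic nitrogen, with methyl in place of propyl, and shows that this site also moves the number, though no measured evidence explains either step.

The compounds shown compare only hydrogen and chloro at this ring position, so the outcome with a fluoro or methoxy group there remains open. Also open, going by these compounds, are whether a butyl chain would continue the trend from methyl to propyl, and whether the chloro step would hold with propyl on the shared core.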